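Chloro for hydrogen on a second pyrazole core

A few compounds are considered here, and "the series" means these few. Any claim that something is new, unique, unknown or untested is made for them only; others in the source may bear on it.

Measured compounds:
compound 1, `COc1ccc(OC)c(-c2cc(-c3ccccc3)nn2-c2ccc(S(=O)(=O)NC(C)=O)cc2)c1`, 15400 nM
compound 2, `COc1ccc(OC)c(-c2cc(-c3ccc(Cl)cc3)nn2-c2ccc(S(=O)(=O)NC(C)=O)cc2)c1`, 10700 nM
compound 3, `NS(=O)(=O)c1ccc(-n2nc(-c3ccccc3)cc2-c2cc(O)ccc2O)cc1`, 61900 nM

In a functional assay on cells (Melanoma cell, Homo sapiens) for cytotoxicity, read by sulforhodamine B assay, with a stated time of 48 h (on this read-out higher numbers stand for weaker inhibition of growth and lower numbers for stronger inhibition of growth), compound 1 gives 15400 nM and compound 2 gives 10700 nM. The change between them is chloro in place of hydrogen on an aromatic carbon, and it made a step of a 1.4-fold lower number from compound 1 to compound 2 (0.16 log units; within the scatter). Compound 3, `NS(=O)(=O)c1ccc(-n2nc(-c3ccccc3)cc2-c2cc(O)ccc2O)cc1`, belongs to a different core; the difference between the two cores is not broken down here. In this assay compound 3 gives 61900 nM, the highest of the three numbers. Compound 4, `NS(=O)(=O)c1ccc(-n2nc(-c3ccc(Cl)cc3)cc2-c2cc(O)ccc2O)cc1`, carries the same change on the core of compound 3: chloro in place of hydrogen on an aromatic carbon. Since the earlier step of a 1.4-fold lower number from compound 1 to compound 2 (0.16 log units; within the scatter) stayed within the scatter, the step from compound 3 to compound 4 is expected to be similar and small, a 1.4-fold lower number from compound 3 to compound 4 (0.15 log units; within the scatter), resting on compound 3 at 61900 nM. Compound 4 is therefore estimated at 44000 nM, between 20000 nM and 100000 nM.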

Compound 4, concentration for 50% growth inhibition: 14600 nM
The estimate for compound 4 lay 3.0-fold (0.48 log units) above the measured number, and the stated range ends above it.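

In this assay chloro in place of hydrogen gave a 4.2-fold lower number from compound 3 to compound 4 (0.63 log units; beyond the scatter) and so had a larger effect on this core than on the core of compound 1, where the step stayed within the scatter. The size of the step therefore did not carry from one core to the other, and the two steps differ: the same change on two cores in this assay, a 1.4-fold lower number (0.16 log units; within the scatter) from compound 1 to compound 2 and a 4.2-fold lower number (0.63 log units; beyond the scatter) from compound 3 to compound 4, 2.9-fold (0.47 log units) apart, beyond the scatter of two such steps. This rests on a single pair of cores and does not show why the steps differ or how the change would read on any further core.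

The compounds shown leave open which difference between the cores goes with the larger step, the acetylated sulfonamide against the free sulfonamide or the methoxy groups against the hydroxy groups. Also open, on these data alone, is how an amine or a carboxylic acid would read in place of the chloro.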